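Swapping the aryl group on the ring amine of compound 1

The compounds below may be only part of what the source reports. "The series", "measured", "known", "first", "only" and "open" are said of these compounds alone.

Of the compounds shown here, two have been measured in a functional assay on cells for antagonist activity at D(4) dopamine receptor (Homo sapiens), read by TR-FRET and cAMP accumulation, with a stated time of 30 min; a lower number here means a stronger inhibitor, a higher number a weaker inhibitor. Compound 1 `Cc1cccc(NC(=O)CN2CCN(c3ccc(Cl)cn3)CC2)c1` gives 4700 nM, the lowest of the two numbers. Compound 2 `O=C(CN1CCN(c2ccc(Cl)cn2)CC1)Nc1cccnc1` gives 40000 nM. Among the compounds with values here, the single measured step, an 8.5-fold higher number from compound 1 to compound 2 (0.93 log units; beyond the scatter), alters the group on the amide-type nitrogen and leaves the rest of the shared core untouched.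

Compound 3 `Cc1cccc(NC(=O)CN2CCN(c3ncccn3)CC2)c1` differs from compound 1 at the opposite end of the molecule: pyrimidin-2-yl in place of 5-chloropyridin-2-yl on an amine nitrogen in a ring, on an amine nitrogen in a ring of a six-membered non-aromatic ring with 2 nitrogen. Within the data shown here, no measured step bears on this position; the step from compound 1 to compound 2 concerns the amide-type nitrogen only and gives no direct guide for the ring amine. The expectation therefore rests on the change itself, in which the chlorine leaves and a second ring nitrogen enters, and it carries a wide uncertainty. A weakening of this assay is expected. Compound 3 is estimated to give 12000 nM, within a range from 3000 nM to 50000 nM, which corresponds to an expected step of a 2.6-fold higher number from compound 1 to compound 3 (0.41 log units; beyond the scatter).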

Compound 3, half-maximal inhibitory concentration: 463 nM
For compound 3 the middle estimate is 26-fold (1.41 log units) above the measured one; measured number outside the range, below it.
By their numbers in this assay, from the lowest: compound 3; then compound 1; then compound 2.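

The ring-amine end of the molecule proves to be a position that can move the number strongly in this assay: pyrimidin-2-yl in place of 5-chloropyridin-2-yl on the amine nitrogen in the ring gives a 10-fold lower number from compound 1 to compound 3 (1.01 log units; beyond the scatter), towards a stronger inhibitor. Within the data shown here, the only earlier step, an 8.5-fold higher number from compound 1 to compound 2 (0.93 log units; beyond the scatter), changed the other end of the molecule and ran towards a weaker inhibitor, so changes made to compound 1 at these two places have now moved the number in opposite directions. No evidence is available that explains the gain seen with compound 3.

This single step combines the departure of the chlorine with the entry of a second ring nitrogen, so the compounds shown leave open which of the two changes accounts for the shift, a question that an unsubstituted pyridin-2-yl or a 5-chloropyrimidin-2-yl group on the same amine nitrogen would help to settle. They also leave open whether pyrimidin-2-yl keeps its effect when the 3-methylphenyl group on the amide-type nitrogen is replaced by pyridin-3-yl.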